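A Carboxymethyl Amide in Place of the Amino Chain

The source may hold more compounds than are shown below. What is called first, only, known or untested is meant among the compounds shown, and "the series" means these compounds.

Measured in a functional assay on HepG2 cells (Homo sapiens), read by MTT assay, with a stated time of 48 h; on this read-out higher numbers stand for weaker inhibition and lower numbers for stronger inhibition:
compound 1 `CCn1c(C(=O)NCCCN(C)C)ccc1C(CC)(CC)c1ccc(OCC(=O)C(C)(C)C)c(C)c1` gives 960 nM
compound 2 `CCN(CC)CCNC(=O)c1ccc(C(CC)(CC)c2ccc(OCC(O)C(C)(C)C)c(C)c2)n1CC` gives 490 nM
compound 3 `CCn1c(C(=O)NCCCN(C)C)ccc1C(CC)(CC)c1ccc(OCC(O)C(C)(C)C)c(C)c1` gives 360 nM

Compound 1 lies within the scatter of compound 2, but the two compounds it is compared with do not stand alike: a 2.7-fold lower number from compound 1 to compound 3 (0.43 log units; beyond the scatter) is a step beyond the scatter, and it comes from replacing (tert-butyl)carbonyl with 1-hydroxy-2,2-dimethylpropyl, away from the carbonyl carbon at issue here.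

Compound 4 `CCn1c(C(=O)N(C)CC(=O)O)ccc1C(CC)(CC)c1ccc(OCC(=O)C(C)(C)C)c(C)c1` keeps the core of compound 1 and changes on a carbonyl carbon: (carboxymethyl)(methyl)amino in place of (3-(dimethylamino)propyl)amino on a carbonyl carbon. Within the data shown here, the only measured step in this chain is a 1.4-fold lower number from compound 2 to compound 3 (0.13 log units; within the scatter), which lies within the scatter, yet it merely exchanges one amino chain for another. Among the measured compounds shown here, no measured compound has lost the amino end, so the data barely cover this change. A higher number is tentatively expected in this assay, and the expected size is a 3.1-fold higher number from compound 1 to compound 4 (0.49 log units; beyond the scatter). The estimated value for compound 4 is 3000 nM (range 600 nM to 15000 nM).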

Compound 4, half-maximal inhibitory concentration: 25200 nM
Estimate against measurement, compound 4: 8.4-fold (0.92 log units) below; the whole stated range lies below it.
By their numbers in this assay, from the lowest: compounds 3, 2 and 1 (each within the scatter of the next, the first and the last beyond it); then compound 4.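

In this assay, this position on the carbonyl carbon turns out to be far from indifferent to the chain it carries: (carboxymethyl)(methyl)amino in place of (3-(dimethylamino)propyl)amino gives a 26-fold higher number from compound 1 to compound 4 (1.42 log units; beyond the scatter), whereas exchanging one amino chain for another gave only a 1.4-fold lower number from compound 2 to compound 3 (0.13 log units; within the scatter). Compound 4 is the only compound shown whose chain ends in a carboxylic acid rather than an amine, and its number stands apart from the other three. No available evidence bears on the reason for this large step.

On these data alone, what remains open is whether the step follows from losing the amine, gaining the carboxylic acid, or adding the methyl on the amide nitrogen. The methyl ester of the same chain, or a (3-(dimethylamino)propyl) chain on a methylated amide nitrogen, would help separate these changes.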